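Swapping the amide ring: cyclopentyl to 4,4-difluorocyclohexyl

A few compounds are considered here, and "the series" means these few. Any claim that something is new, unique, unknown or untested is made for them only; others in the source may bear on it.

Compound 1 `CC1CC(C(=O)N2CCc3nc(C#Cc4ccccc4)sc3C2)C1` gives 81 nM in an assay on HEK293 cells for positive allosteric modulation of metabotropic glutamate receptor 5 (Homo sapiens), read by FLIPR, with a stated time of 1 h; on this read-out lower numbers stand for an effect already at smaller amounts and higher numbers for an effect only at larger amounts of compound
Compound 2 `O=C(C1CC(F)C1)N1CCc2nc(C#Cc3ccccc3)sc2C1` gives 85 nM in this assay
Compound 3 `O=C(C1CCCC1)N1CCc2nc(C#Cc3ccccc3)sc2C1` gives 19 nM in this assay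

Compound 3 stands at the lowest number of the three in this assay, and its steps to compound 1 and to compound 2 both lie beyond the scatter. Compound 4 `O=C(C1CCC(F)(F)CC1)N1CCc2nc(C#Cc3ccccc3)sc2C1` differs from compound 3 in one place: 4,4-difluorocyclohexyl in place of cyclopentyl on a carbonyl carbon. Among the compounds with values here, no measured pair covers this exact change. The steps that touch the same carbonyl carbon, a 4.3-fold lower number from compound 1 to compound 3 (0.63 log units; beyond the scatter) and a 4.5-fold lower number from compound 2 to compound 3 (0.65 log units; beyond the scatter), show that exchanging the ring there shifts the number modestly, while a 1.0-fold higher number from compound 1 to compound 2 (0.02 log units; within the scatter) shows that fluorine on such a ring barely matters. A modest shift in either direction is therefore expected, centred a little higher than the number of compound 3. For compound 4 the expected value is 40 nM, between 12 nM and 140 nM, which means an expected step of a 2.1-fold higher number from compound 3 to compound 4 (0.32 log units; beyond the scatter).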

Compound 4, half-maximal effective concentration: 70 nM
Compound 4: the middle estimate sits 1.8-fold (0.24 log units) below what was measured; measured number inside the range.
By their numbers in this assay, from the lowest: compound 3; then compounds 4, 1 and 2 (each within the scatter of the next).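

At this carbonyl carbon, 4,4-difluorocyclohexyl does not hold the low number of cyclopentyl in this assay, with a 3.7-fold higher number from compound 3 to compound 4 (0.57 log units; beyond the scatter). It falls in with the 3-fluorocyclobutyl and 3-methylcyclobutyl amides, with a 1.2-fold lower number from compound 2 to compound 4 (0.08 log units; within the scatter) and a 1.2-fold lower number from compound 1 to compound 4 (0.06 log units; within the scatter), so among these four rings only cyclopentyl stands apart. Nothing available explains this result.

Open, going by these compounds, is whether plain cyclohexyl would group with compound 3 or compound 4, which would separate the larger ring from its two fluorines. Also open, on these data alone, is how a ring carrying an amine, such as piperidinyl, would behave here.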